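Swapping the Heterocycle on Sulfur in a Weak Inhibitor Series

The source may report more compounds than this note shows. Statements on the series, on what has been measured and on what is new or still open speak of the compounds shown alone.

Compound 3 `CC(C)[C@H](NC(=O)COc1cccc2ccccc12)C(=O)N[C@@H](CC(=O)O)C(=O)CSc1nnc(-c2ccccc2)o1` is the only one of three close relatives that yields an actual number in a functional assay on Jurkat cells (Homo sapiens) for inhibition; a higher number here means a weaker inhibitor, a lower number a stronger inhibitor: compound 3 gives 150000 nM. Compound 1 `CCOC(=O)c1c(C)noc1OCC(=O)[C@H](CC(=O)O)NC(=O)[C@@H](NC(=O)COc1cccc2ccccc12)C(C)C` reaches only the limit of the assay in this assay, giving > 200000 nM. Compound 2 `CC(C)[C@H](NC(=O)COc1cccc2ccccc12)C(=O)N[C@@H](CC(=O)O)C(=O)CSC1=NCCS1` likewise stops at the assay limit in this assay, with > 200000 nM. The unmeasured compound 4 `Cc1cc(C)nc(SCC(=O)[C@H](CC(=O)O)NC(=O)[C@@H](NC(=O)COc2cccc3ccccc23)C(C)C)n1` differs from compound 3 in one place: 4,6-dimethylpyrimidin-2-yl in place of 5-phenyl-1,3,4-oxadiazol-2-yl on a sulfur. The step that bears most directly on this change is the one at the same sulfur, an at least 1.3-fold lower number from compound 2 to compound 3 (0.12 log units; that floor lies within the scatter); the related step at the same chain carbon, an at least 1.3-fold lower number from compound 1 to compound 3 (0.12 log units; that floor lies within the scatter), reads the same way. Both rest on (the limit of > 200000 nM in this assay, at which 2 of the 3 values shown sit), so they leave the true size of either step open. Nothing here points to a large move in either direction, so for compound 4 the expected step is no change at the digits printed from compound 3 to compound 4 (within the scatter). Compound 4 is therefore estimated at 150000 nM, within a range from 60000 nM to 400000 nM, with a real chance that only a limit is reported.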

Compound 4, half-maximal inhibitory concentration: > 200000 nM
Compound 4 ended at the assay's limit; the forecaster's own chance of this, stated with the estimate: 50%; middle value at least 1.3-fold (0.12 log units) from the limit.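

In this assay, placing 4,6-dimethylpyrimidin-2-yl on the sulfur instead of 5-phenyl-1,3,4-oxadiazol-2-yl gives an at least 1.3-fold higher number from compound 3 to compound 4 (0.12 log units; that floor lies within the scatter), so this second aromatic ring brings no readable gain over the first. Within the data shown here, the value of compound 4 is a limit, which leaves compound 3 as the only compound with an actual number, and the steps from compound 1 and compound 2 to compound 4 cannot be read. The true size of the step from the oxadiazole to the pyrimidine stays unknown because it rests on a limit: the limit of > 200000 nM in this assay, at which 3 of the 4 values shown sit.

From the compounds shown here alone, it remains open whether any group on this sulfur can give a clearly lower number than compound 3, at 150000 nM. The compounds shown also do not tell how a plain ethyl chain or a ring carrying an amine would read at this place.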